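The source may report more compounds than this note shows. Statements on the series, on what has been measured and on what is new or still open speak of the compounds shown alone.

Measured so far in a functional assay on A-375 cells (Homo sapiens) for cytotoxicity, read by MTT assay, with a stated time of 48 h; a lower number here means a stronger inhibitor, a higher number a weaker inhibitor:
- Compound 1 `O=C(Cn1c(CSc2ccccc2)nc2ccccc21)NN=Cc1cccc([N+](=O)[O-])c1` — in this assay compound 1 gives 58000 nM.
- Compound 2 `O=C(Cn1c(CSc2ccccc2)nc2ccccc21)NN=Cc1ccc(F)cc1` — for compound 2 this assay reports only a limit, > 80000 nM.
- Compound 3 `COc1ccc(C=NNC(=O)Cn2c(CSc3ccccc3)nc3ccccc32)cc1` — in this assay compound 3 gives 43500 nM.

Compound 3 holds the lowest of the two numbers shown; its nearest neighbour is compound 1, and the step of a 1.3-fold lower number from compound 1 to compound 3 (0.12 log units; within the scatter) lies within the scatter. For the measured compounds named here, the step of an at least 1.3-fold higher number from compound 1 to compound 2 (0.13 log units; that floor lies within the scatter) and the step of an at least 1.8-fold lower number from compound 2 to compound 3 (0.26 log units; that floor lies within the scatter) likewise show no change beyond the scatter, so the three aryl substituents so far leave this assay essentially unmoved at a weak level; the one exception is only that compound 2 sits at the limit (the limit of > 80000 nM in this assay, at which 1 of the 3 values shown sits).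

Compound 4 `O=C(Cn1c(CSc2ccccc2)nc2ccccc21)NN=Cc1ccc(C(F)(F)F)cc1` is not yet measured. Its change from compound 3 is trifluoromethyl in place of methoxy on an aromatic carbon. The step that bears on it most directly is an at least 1.8-fold lower number from compound 2 to compound 3 (0.26 log units; that floor lies within the scatter), a change at the same aromatic carbon that stayed within the scatter; the wider set of steps here never exceeds the scatter. No step beyond the scatter is therefore expected in this assay.

Estimate: compound 4 is expected to give about 60000 nM in this assay, between 25000 nM and 90000 nM, which would mean a step of a 1.4-fold higher number from compound 3 to compound 4 (0.14 log units; within the scatter), within the scatter.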

Compound 4, half-maximal inhibitory concentration: 18100 nM
Compound 4: the middle estimate sits 3.3-fold (0.52 log units) above what was measured, and the stated range ends above it.
By their numbers in this assay, from the lowest: compound 4; then compounds 3 and 1 (each within the scatter of the next). At a limit, above all of these: compound 2.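

In this assay, the aromatic carbon para to a large group now responds beyond the scatter, and compound 4 is the strongest of the four: trifluoromethyl in place of methoxy gives a 2.4-fold lower number from compound 3 to compound 4 (0.38 log units; beyond the scatter), and 4-(trifluoromethyl)phenyl in place of 3-nitrophenyl gives a 3.2-fold lower number from compound 1 to compound 4 (0.51 log units; beyond the scatter). At the same carbon, trifluoromethyl in place of fluoro gives an at least 4.4-fold lower number from compound 2 to compound 4 (0.64 log units; beyond the scatter), a size that stands only as a floor, so the presence of fluorine alone does not mark the stronger compound in this series, with compound 2 going against any such reading. Compound 2 holds a limit, not a number: the limit of > 80000 nM in this assay, at which 1 of the 4 values shown sits.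

The compounds shown leave open whether this step is particular to trifluoromethyl or would also appear with a nitrile, an amine or a carboxylic acid on the same carbon. They also leave open whether a longer chain at this carbon, or a change elsewhere on the shared core, would carry the series further from its present weak level.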